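Cyclohexyl in place of tert-butyl on the bicyclic acid core

A few compounds are considered here, and "the series" means these few. Any claim that something is new, unique, unknown or untested is made for them only; others in the source may bear on it.

Compound 2 `CC(C)(C)c1nn2cc(Cl)ccc2c1Cc1cccc(C(=O)O)n1` holds the lowest number of the two measured in a functional assay on cells for antagonist activity at prostaglandin E2 receptor EP1 subtype (Rattus norvegicus), read by fluorescence and calcium flux, with a stated time of 60 s (on this read-out lower numbers stand for stronger inhibition and higher numbers for weaker inhibition), giving 48 nM. For the measured compounds named here, its only measured neighbour is compound 1 `O=C(O)c1cccc(Cc2c(-c3ccco3)nn3cc(Cl)ccc23)n1`, which in this assay gives 1200 nM; the step of a 25-fold lower number from compound 1 to compound 2 (1.40 log units; beyond the scatter) came from tert-butyl in place of furan-2-yl on an aromatic carbon. Compound 3 `O=C(O)c1cccc(Cc2c(C3CCCCC3)nn3cc(Cl)ccc23)n1` is not yet measured; it differs from compound 2 by cyclohexyl in place of tert-butyl on an aromatic carbon. Going by the values given here, the one measured step bears on it only loosely: it showed that this position admits a large change with a large gain when furan-2-yl gave way to tert-butyl, but it offers no comparison between two non-aromatic carbon groups. Compound 3 is therefore expected to change little, an expected step of a 1.1-fold lower number from compound 2 to compound 3 (0.03 log units; within the scatter) that need not exceed the scatter. The estimate for compound 3 in this assay is 45 nM, within a range from 12 nM to 170 nM.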

Compound 3, half-maximal inhibitory concentration: 1200 nM
For compound 3 the middle estimate is 27-fold (1.43 log units) below the measured one; measured number above the stated range.
By their numbers in this assay, from the lowest: compound 2; then compounds 1 and 3 (each within the scatter of the next).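

In this assay this position, on an aromatic carbon next to the ring nitrogen, separates two non-aromatic carbon groups sharply, which the earlier pair could not show: cyclohexyl in place of tert-butyl gives a 25-fold higher number from compound 2 to compound 3 (1.40 log units; beyond the scatter) and so loses the whole gain seen earlier. The low number therefore does not extend to every non-aromatic carbon group, and the comparison with the aromatic group gives no change at the digits printed from compound 1 to compound 3 (within the scatter), leaving cyclohexyl and furan-2-yl indistinguishable here. Nothing available explains why tert-butyl and cyclohexyl differ so much.

The compounds shown do not tell whether the low number belongs to tert-butyl alone or would also appear with isopropyl, cyclopropyl or cyclobutyl. They also leave open how a six-membered ring carrying an amine nitrogen would read at this position.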